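Cyclohexyl in Place of Isopropyl: An Expected Value

A few compounds are considered here, and "the series" means these few. Any claim that something is new, unique, unknown or untested is made for them only; others in the source may bear on it.

Compound 1, `COC(=O)c1nc(C)n(-c2ccccc2C(F)(F)F)n1`; in a functional assay on NCI-H226 cells (Homo sapiens) for inhibition, read by MTT assay, with a stated time of 72 h (on this read-out higher numbers stand for weaker inhibition of growth and lower numbers for stronger inhibition of growth), compound 1 gives 6130 nM.
Compound 2, `COC(=O)c1nc(C(C)C)n(-c2ccc(F)cc2)n1`; in this assay compound 2 gives 6170 nM.

Among the two numbers measured, compound 2 holds the higher one, yet its nearest neighbour, compound 1, sits so close that the gap lies within the scatter, and the two cannot be ranked against each other. Compound 3, `COC(=O)c1nc(C2CCCCC2)n(-c2ccc(F)cc2)n1`, has not been measured in this assay. It differs from compound 2 in one place: cyclohexyl in place of isopropyl on an aromatic carbon. Within the data shown here, no pair of measured compounds shows what such an exchange does, so the size of the step rests on judgement alone. The analyst expects only a modest move, if any, most likely toward a somewhat lower number, and not clearly beyond the scatter of repeated measurements. The estimated step is a 1.4-fold lower number from compound 2 to compound 3 (0.14 log units; within the scatter), and it is given with a wide range. Compound 3 is therefore estimated at 4500 nM in this assay, with a range from 1500 nM to 15000 nM.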

Compound 3, concentration for 50% growth inhibition: 6260 nM
Beside the measured number, compound 3's estimate is 1.4-fold (0.14 log units) below it; the measured number falls inside the stated range.
By their numbers in this assay, from the lowest: compounds 1, 2 and 3 (each within the scatter of the next).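

In this assay, among these compounds, the exchange of isopropyl for cyclohexyl on the aromatic carbon gives a 1.0-fold higher number from compound 2 to compound 3 (0.01 log units; within the scatter) and so provides the first measured step at this position, where earlier there was only a judgement. Within this one pair, the read-out does not separate the two groups, although cyclohexyl brings a six-membered non-aromatic ring of carbon only and isopropyl has no ring, and neither group has hydrogen-bond donors, hydrogen-bond acceptors or a net charge. The data offer nothing that would explain this result.

All three compounds lie within the scatter of one another, and this single step says nothing about what a group of another kind would do at the same aromatic carbon, such as an amine, a carboxylic acid, a phenyl ring or a longer alkyl chain. On these data alone, it also remains open whether the same exchange would read alike with the trifluoromethyl-bearing phenyl group of compound 1 on the ring nitrogen, or with an amide or a carboxylic acid in place of the methoxycarbonyl group.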